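Methyl on the Aromatic Ring: Cytotoxicity in Two Related Series

The compounds below may be only part of what the source reports. "The series", "measured", "known", "first", "only" and "open" are said of these compounds alone.

Measured compounds:
Compound 1, `CCCC[C@@H](CCn1cncn1)c1ccccc1`, gives 47.5 ug/mL in an ADME assay on RD cells (Homo sapiens) for cytotoxicity, read by MTT assay, with a stated time of 3 days; on this read-out higher numbers stand for lower toxicity in this test and lower numbers for higher toxicity in this test.
Compound 2, `CCCC[C@@H](CCn1cncn1)c1ccc(C)cc1`, gives 56.5 ug/mL in this assay.
Compound 3, `c1ccc(C[C@H](CCn2cncn2)c2ccccc2)cc1`, gives 55.4 ug/mL in this assay.

Compound 2 differs from compound 1 by methyl in place of hydrogen on an aromatic carbon, and this change gave a 1.2-fold higher number from compound 1 to compound 2 (0.08 log units; within the scatter). Compound 4, `Cc1ccc(C[C@H](CCn2cncn2)c2ccccc2)cc1`, has not yet been measured; it differs from compound 3 by methyl in place of hydrogen on an aromatic carbon, the same change at the same kind of place. The difference between the two cores, that of compound 1 and that of compound 3, is not broken down here. Because compound 1 and compound 2 show a 1.2-fold higher number from compound 1 to compound 2 (0.08 log units; within the scatter), a step of similar size is expected in this assay, namely a 1.1-fold higher number from compound 3 to compound 4 (0.05 log units; within the scatter). Compound 4 is therefore estimated at 62 ug/mL, with a range from 38 ug/mL to 100 ug/mL.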

Compound 4, half-maximal cytotoxic concentration: 37.8 ug/mL
For compound 4 the middle estimate is 1.6-fold (0.21 log units) above the measured one; measured number outside the range, below it.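

In this assay, methyl in place of hydrogen on the core of compound 3 gives a 1.5-fold lower number from compound 3 to compound 4 (0.17 log units; within the scatter). Set beside the earlier step, the two readings cannot be told apart: the same change on two cores in this assay, a 1.2-fold higher number (0.08 log units; within the scatter) from compound 1 to compound 2 and a 1.5-fold lower number (0.17 log units; within the scatter) from compound 3 to compound 4, 1.7-fold (0.24 log units) apart, within the scatter of two such steps. The change therefore carries from one core to the other only in that neither step moves the number beyond the scatter; this does not show that the step keeps a fixed size or direction on both cores.

The compounds shown leave open whether a different group at the same place, such as an amine, a carboxylic acid or a methoxy group, would give a step beyond the scatter. They also leave open what a longer chain there would do on either core.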